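Replacing dimethoxyphenyl with chlorophenyl on a weaker sulfone

The source may hold more compounds than are shown below. What is called first, only, known or untested is meant among the compounds shown, and "the series" means these compounds.

In a functional assay on PC-3 cells (Homo sapiens) for cytotoxicity, read by MTT assay, with a stated time of 72 h (on this read-out lower numbers stand for stronger inhibition and higher numbers for weaker inhibition), compound 1 `COc1cc(Nc2nc3ccccc3nc2S(=O)(=O)c2ccccc2)cc(OC)c1` gives 140 nM. Compound 2 `O=S(=O)(c1ccccc1)c1nc2ccccc2nc1Nc1ccc(Cl)cc1` gives 15300 nM, and compound 3 `COc1cc(Nc2nc3ccccc3nc2S(=O)(=O)c2ccc(C)cc2)cc(OC)c1` gives 2940 nM, the second highest of the three numbers, between compound 1 and compound 2. Compound 4 `Cc1ccc(S(=O)(=O)c2nc3ccccc3nc2Nc2ccc(Cl)cc2)cc1` is not yet measured in this assay. It differs from compound 3 in one place: 4-chlorophenyl in place of 3,5-dimethoxyphenyl on a nitrogen on an aromatic ring. The same exchange was already seen once, from compound 1 to compound 2, where it gave a 110-fold higher number from compound 1 to compound 2 (2.04 log units; beyond the scatter); the step of a 21-fold higher number from compound 1 to compound 3 (1.32 log units; beyond the scatter) shows the methyl itself also weakens. Applying the earlier exchange to compound 3, the number for compound 4 is expected to rise by about a 34-fold higher number from compound 3 to compound 4 (1.53 log units; beyond the scatter). Compound 4 is therefore estimated at 100000 nM, with a range from 15000 nM to 600000 nM.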

Compound 4, half-maximal inhibitory concentration: 9660 nM
For compound 4 the middle estimate is 10-fold (1.02 log units) above the measured one; the measured number lies below the stated range.
By their numbers in this assay, from the lowest: compound 1; then compound 3; then compounds 4 and 2 (each within the scatter of the next).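

With the methyl present, moving to 4-chlorophenyl on the nitrogen costs far less, with a 3.3-fold higher number from compound 3 to compound 4 (0.52 log units; beyond the scatter), so the size of this change depends on the rest of the molecule: the same change on two cores in this assay, a 110-fold higher number (2.04 log units; beyond the scatter) from compound 1 to compound 2 and a 3.3-fold higher number (0.52 log units; beyond the scatter) from compound 3 to compound 4, 33-fold (1.52 log units) apart, beyond the scatter of two such steps. The methyl, which weakened compound 1, makes no clear difference once 4-chlorophenyl is in place, with a 1.6-fold lower number from compound 2 to compound 4 (0.20 log units; within the scatter): the same change on two cores in this assay, a 21-fold higher number (1.32 log units; beyond the scatter) from compound 1 to compound 3 and a 1.6-fold lower number (0.20 log units; within the scatter) from compound 2 to compound 4, 33-fold (1.52 log units) apart, beyond the scatter of two such steps. The two changes therefore do not simply add up in this assay. On these data alone, what lies behind this remains open, as does whether an amine or a longer chain in place of the methyl would show the same dependence.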